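A few compounds are considered here, and "the series" means these few. Any claim that something is new, unique, unknown or untested is made for them only; others in the source may bear on it.

Measured so far:
compound 1, `Cc1oc(C(=O)O)cc1COc1ccc(-c2ccncc2)cc1`: > 10000 nM
compound 2, `CC(C)c1oc(C(=O)O)cc1COc1ccc(-c2ccccc2)cc1`: 3000 nM
compound 3, `Cc1noc(C)c1S(=O)(=O)NC(=O)c1cc(COc2ccc(-c3ccc(OC(F)F)cc3)cc2)c(C)o1`: 0.6 nM

The three measured compounds were tested in an assay on cells for displacement of a labelled ligand from prostaglandin E2 receptor EP4 subtype (Homo sapiens), read by scintillation counting; on this read-out higher numbers stand for weaker inhibition and lower numbers for stronger inhibition. For compound 1 the result is a limit of the assay and not a number; it sits at the limit of > 10000 nM in this assay, at which 1 of the 3 values shown sits. Among the two numbers, compound 2 has the highest, and the value of compound 3 is far lower, well beyond the scatter of repeated measurements.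

The step followed here leads from compound 2 to compound 4, whose structure is `Cc1oc(C(=O)O)cc1COc1ccc(-c2ccccc2)cc1`. The change is methyl in place of isopropyl on an aromatic carbon. Within the data shown here, compound 4 thus shares the methyl-bearing core of compound 1 but keeps the unsubstituted phenyl of compound 2, so no measured pair gives the size of this change directly. With compound 1 at the limit and compound 2 already the weaker of the two numbers, the expectation is a rise in this assay, that is weaker inhibition, of a size around or somewhat beyond the scatter, with a real chance that only a limit is reported. The estimated step is a 2.7-fold higher number from compound 2 to compound 4 (0.43 log units; beyond the scatter). Compound 4 is therefore expected to give about 8000 nM, within a range of 2000 nM to 30000 nM.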

Compound 4, inhibition constant: 420 nM
Compound 4: middle estimate off by 19-fold (1.28 log units), on the high side, outside the stated range (below it).
By their numbers in this assay, from the lowest: compound 3; then compound 4; then compound 2. At a limit, above all of these: compound 1.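

With the unsubstituted phenyl kept, this assay shows a 7.1-fold lower number from compound 2 to compound 4 (0.85 log units; beyond the scatter), so on the aromatic carbon next to the ring oxygen, methyl gives stronger inhibition than isopropyl, and the larger group is not needed to reach this level. With the methyl kept, phenyl in place of pyridin-4-yl gives an at least 23-fold lower number from compound 1 to compound 4 (1.37 log units; beyond the scatter), so the methyl on its own does not account for the weak result of compound 1. That step gives only a minimum size, since the result for compound 1 is a limit and not a number: the limit of > 10000 nM in this assay, at which 1 of the 4 values shown sits.

Among these compounds, whether ethyl, cyclopropyl or a plain hydrogen on this carbon would do better or worse than methyl stays open, since only two groups have been compared here with the rest of the molecule unchanged. Compound 3, at 0.6 nM, differs from compound 4 in more than one place, so the shares of its acyl sulfonamide and of the difluoromethoxy group on its outer phenyl cannot be read from the compounds shown.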